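The compounds below may be only part of what the source reports. "The series", "measured", "known", "first", "only" and "open" are said of these compounds alone.

Measured compounds:
- compound 1, `CSc1nc(NCCCCCO)c2ccccc2n1`: 62000 nM
- compound 2, `COc1ccc(CNc2nc(SC)nc3ccccc23)cc1`: 30900 nM
- compound 3, `CSc1nc(Nc2ccccc2)c2ccccc2n1`: 78400 nM

These three compounds share one core and were compared in a functional assay on MCF7 cells (Homo sapiens) for cytotoxicity, read by MTT assay, with a stated time of 72 h; a higher number here means a weaker inhibitor of growth, a lower number a stronger inhibitor of growth. Compound 1 gives 62000 nM, which is the second highest of the three numbers; the values of compound 2 and compound 3 both lie within the usual scatter of it, so no order among them can be read off.

Compound 4, `CSc1nc(NCCCCc2ccccc2)c2ccccc2n1`, differs from compound 1 in one place: phenyl in place of hydroxymethyl on a saturated chain carbon, four bonds along the chain from a nitrogen on an aromatic ring. For the measured compounds named here, the one measured step that bears on this change is a 1.3-fold higher number from compound 1 to compound 3 (0.10 log units; within the scatter), where a phenyl took the place of the whole 5-hydroxypentyl chain without moving the number beyond the scatter. The values of compound 1 and compound 2 also differ only within the scatter. Nothing in these numbers therefore points to a step beyond the scatter in either direction, and compound 4 is expected to read close to compound 1, with a 1.1-fold lower number from compound 1 to compound 4 (0.05 log units; within the scatter). The estimate for compound 4 is 55000 nM, in the range 22000 nM to 130000 nM.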

Compound 4, concentration for 50% growth inhibition: 32000 nM
The estimate for compound 4 lay 1.7-fold (0.24 log units) above the measured number; measured number inside the range.
By their numbers in this assay, from the lowest: compounds 2, 4, 1 and 3 (each within the scatter of the next, the first and the last beyond it).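

In this assay, phenyl in place of hydroxymethyl gives a 1.9-fold lower number from compound 1 to compound 4 (0.29 log units; within the scatter), so at this place on the chain, a six-membered aromatic ring of carbon only can replace a group carrying a hydrogen-bond donor and acceptor without a step beyond the scatter. The earlier phenyl step replaced the whole 5-hydroxypentyl chain, whereas this one keeps the chain up to that carbon and shows that the result also holds when only the group on the chain is exchanged. No measurement is available that would explain the size of this step.

On these data alone, whether another group at this place, such as an amine or a carboxylic acid, would give a step beyond the scatter remains open. So does whether phenyl on a shorter or a longer chain would read the same.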